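The compounds below may be only part of what the source reports. "The series", "measured", "known", "first", "only" and "open" are said of these compounds alone.

Measured compounds in an assay on Prostate gland for inhibition of steroid 5-alpha-reductase (Rattus norvegicus); a lower number here means a stronger inhibitor, a higher number a weaker inhibitor:
- compound 1, `CCCC(c1ccccc1)n1ccc2cc(/C(C)=C/C(=O)Nc3ccccc3OCCCC(=O)O)ccc21`: 9.1 nM
- compound 2, `C/C(=C\C(=O)Nc1ccccc1OCCCC(=O)O)c1ccc2c(ccn2C(c2ccccc2)C(C)C)c1`: 25 nM
- compound 3, `C/C(=C\C(=O)Nc1ccccc1OCCCC(=O)O)c1ccc2c(ccn2C(CC(C)C)c2ccccc2)c1`: 6.3 nM

Compound 3 gives the lowest number of the three. The step of a 1.4-fold lower number from compound 1 to compound 3 (0.16 log units; within the scatter) is within the scatter, so compound 1 and compound 3 cannot be told apart; the step of a 4.0-fold lower number from compound 2 to compound 3 (0.60 log units; beyond the scatter) is beyond it.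

Compound 4, `C/C(=C\C(=O)Nc1ccccc1OCCCC(=O)O)c1ccc2c(ccn2C(c2ccccc2)c2ccc(C(F)(F)F)cc2)c1`, differs from compound 3 by 4-(trifluoromethyl)phenyl in place of isobutyl on a saturated chain carbon bound to an aromatic carbon and an aromatic nitrogen. The measured steps at this same carbon are a 2.7-fold higher number from compound 1 to compound 2 (0.44 log units; beyond the scatter) and a 4.0-fold lower number from compound 2 to compound 3 (0.60 log units; beyond the scatter): of the three alkyl groups tried there, isopropyl gives the highest number, while propyl and isobutyl sit within the scatter of each other. Within the data shown here, no measured step exchanges an alkyl group at this carbon for a ring, so there is no direct precedent for the 4-(trifluoromethyl)phenyl group. All changes seen at this carbon stayed modest, which suggests the position tolerates variation without large swings.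

Compound 4 is therefore expected at 12 nM, with a range from 3 nM to 50 nM, the range being wide for lack of a precedent. This expectation corresponds to a 1.9-fold higher number from compound 3 to compound 4 (0.28 log units; within the scatter).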

Compound 4, half-maximal inhibitory concentration: 8.1 nM
Compound 4: middle estimate off by 1.5-fold (0.17 log units), on the high side; low and high end bracket the measured number.
By their numbers in this assay, from the lowest: compounds 3, 4 and 1 (each within the scatter of the next); then compound 2.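

In this assay, the saturated chain carbon bound to an aromatic carbon and an aromatic nitrogen now has a measured ring substituent as well as alkyl groups, and the exchange of isobutyl for 4-(trifluoromethyl)phenyl, with its 10 heavy atoms against 4, gives a 1.3-fold higher number from compound 3 to compound 4 (0.11 log units; within the scatter) and so no detectable change. The exchange of propyl for the same ring gives a 1.1-fold lower number from compound 1 to compound 4 (0.05 log units; within the scatter) and likewise leaves the two compounds indistinguishable, whereas the exchange of isopropyl for it gives a 3.1-fold lower number from compound 2 to compound 4 (0.49 log units; beyond the scatter) and leaves compound 2 as the only one of the four set apart from all the others, so at this carbon the ring matches the propyl and isobutyl groups rather than the isopropyl group. No supporting evidence is available to account for these similarities or for the separate standing of compound 2.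

A plain phenyl, a 4-fluorophenyl or a cyclohexyl at this carbon would show whether the trifluoromethyl group or the aromatic ring matters to the reading at all. An amine or a carboxylic acid on the chain at this carbon would test how far the tolerance seen so far extends.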